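Swapping a fluorinated benzyl group for a propargyl group

A few compounds are considered here, and "the series" means these few. Any claim that something is new, unique, unknown or untested is made for them only; others in the source may bear on it.

Of the compounds shown here, three sharing one core have been tested in an ADME assay on cells for inhibition of cytochrome P450 1A1 (Homo sapiens), read by fluorescence, tested at 10 uM; on this read-out lower numbers stand for less inhibition and higher numbers for more inhibition at the one concentration tested (going by the name of the read-out). Compound 1 `COc1cc(-c2nc3ccccc3c(=O)[nH]2)ccc1OCc1ccc(Cl)cc1Cl` gives 24.1%, compound 2 `COc1ccc(-c2nc3ccccc3c(=O)[nH]2)cc1OCc1ccc(F)cc1F` gives 23.8%, and compound 3 `COc1cc(-c2nc3ccccc3c(=O)[nH]2)ccc1OCc1ccc(F)cc1` gives 24.9%. Compound 2 sits among these with the other two numbers within the usual scatter of it, so no ordering can be claimed. For the measured compounds named here, the one measured step, a number 0.8 percentage points higher from compound 1 to compound 3 (within the scatter), shows that exchanging one halogenated ring for another left the read-out essentially unchanged. Compound 4 `C#CCOc1cc(-c2nc3ccccc3c(=O)[nH]2)ccc1OC` carries a different kind of change: ethynyl in place of 2,4-difluorophenyl on a saturated chain carbon bound to an oxygen on an aromatic ring. Going by the values given here, no measured step tests the loss of an aromatic ring here, so the expectation rests on the absence of movement seen so far. Compound 4 is expected to give 22% in this assay, within 6% to 38%, a step of a number 1.8 percentage points lower from compound 2 to compound 4 (within the scatter) that is expected to stay within the scatter.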

Compound 4, a percentage reported as inhibition, at one concentration (the size of the read-out at that concentration, not a potency): 22.8%
Compound 4: the middle estimate sits 0.8 percentage points below what was measured, and the stated range covers the measured number.
By their numbers in this assay, from the lowest: compounds 4, 2, 1 and 3 (each within the scatter of the next).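

In this assay, replacing the whole 2,4-difluorophenyl ring with the much smaller ethynyl, on a saturated chain carbon bound to an oxygen on an aromatic ring, gives a number 1 percentage points lower from compound 2 to compound 4 (within the scatter). The earlier step only exchanged one halogenated ring for another, whereas this one shows that the read-out holds with no such ring at this position. No measurement here explains this lack of movement.

As far as these compounds go, whether an amine or a carboxylic acid on this chain carbon would move the number remains open.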